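Aryl swap on the triazole nitrogen of compound 2

This account rests on a few compounds, and the source may have more. Where it says the series, first, only, none or still open, it means among the compounds named here.

Two compounds of the series have numbers in a functional assay on MCF7 cells (Homo sapiens) for inhibition, read by sulforhodamine B assay, with a stated time of 48 h, tested at 50 uM; on this read-out higher numbers stand for more inhibition of growth at the one concentration tested and lower numbers for less inhibition of growth. Compound 2 `COc1ccc([C@@H]2C/C(=N/OCc3cn(-c4ccc(C#N)cc4)nn3)c3cc(CC=C(C)C)c(OC)cc3O2)cc1` gives 40%, the lower of the two numbers shown. Compound 1 `COc1ccc([C@@H]2C/C(=N/OCc3cn(-c4cccc(CO)c4)nn3)c3cc(CC=C(C)C)c(OC)cc3O2)cc1` gives 42% in this assay, and the step of a number 2 percentage points lower from compound 1 to compound 2 (within the scatter) lies within the scatter, so the two numbers cannot be told apart. Going by the values given here, the only measured change, 4-cyanophenyl in place of 3-(hydroxymethyl)phenyl on an aromatic nitrogen, thus left the read-out of this assay unchanged beyond the scatter.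

Compound 3 `COc1ccc([C@@H]2C/C(=N/OCc3cn(-c4cccnc4Cl)nn3)c3cc(CC=C(C)C)c(OC)cc3O2)cc1` carries the change (2-chloropyridin-3-yl in place of 4-cyanophenyl on an aromatic nitrogen). Among the compounds with values here, this is the same kind of exchange as the one measured step, a new aryl group on the aromatic nitrogen of the triazole, and that step was small. Within the data shown here, with only one step to go on, and that one within the scatter, no step beyond the scatter is expected in this assay for compound 3 either, in neither direction. Compound 3 is therefore expected to give about 40% in this assay, with a range from 25% to 55%. The expected step is no change at the digits printed from compound 2 to compound 3 (within the scatter).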

Compound 3, percent growth inhibition at one concentration: 35%
Estimate against measurement, compound 3: 5 percentage points above; low and high end bracket the measured number.
By their numbers in this assay, from the lowest: compounds 3, 2 and 1 (each within the scatter of the next).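

In this assay the step of a number 5 percentage points lower from compound 2 to compound 3 (within the scatter) and the step of a number 7 percentage points lower from compound 1 to compound 3 (within the scatter) both come with 2-chloropyridin-3-yl entering on the aromatic nitrogen, in place of 4-cyanophenyl and of 3-(hydroxymethyl)phenyl. Going by these compounds alone, until now this position had carried only six-membered aromatic rings of carbon; a ring with 1 hetero atom and a chlorine now stands there too, and no step among the three compounds lies beyond the scatter, so the three aryl groups cannot be ranked. No measurement on hand bears on why these numbers lie so close together.

As far as these compounds go, all three groups on this nitrogen are six-membered aromatic rings, so it stays open whether any group at this position can move the number beyond the scatter. A benzyl group, a phenyl ring bearing a carboxylic acid or a dimethylamino group, or a longer alkyl chain in place of the aryl ring would test this, and a single tested concentration leaves open how the compounds compare across a range of concentrations.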